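The compounds below may be only part of what the source reports. "The series", "measured", "known", "first", "only" and "open" are said of these compounds alone.

Compound 1 `CC(C)c1ccc2c(CCCCNS(=O)(=O)c3ccccc3)cc(C(=O)O)c-2cc1` was tested in a functional assay (plasma) for inhibition, with Oryctolagus cuniculus as the target; a higher number here means a weaker inhibitor, a lower number a stronger inhibitor. In this assay compound 1 gives only the limit > 100000 nM. Compound 2 `CC(C)c1ccc2c(CCCCNS(=O)(=O)c3ccccc3)cc(S(=O)(=O)O)c-2cc1` likewise gives only the limit > 100000 nM in this assay. The step from compound 1 to compound 2, a step that the two limits leave unreadable from compound 1 to compound 2, stays unreadable because both values sit at the limit of > 100000 nM in this assay, at which 2 of the 2 values shown sit. Compound 3 `CC(C)c1ccc2c(CCCCNS(=O)(=O)c3ccccc3)cc(CC(=O)O)c-2cc1` differs from compound 2 by carboxymethyl in place of sulfo on an aromatic carbon. Going by the values given here, no measured step reaches beyond the shared limit, so nothing readable bears on this change. Compound 3 is therefore expected to remain at the limit, with an estimate of 150000 nM and a range from 50000 nM to 500000 nM. The expected step that the limit leaves unreadable from compound 2 to compound 3 is judged as none beyond the scatter.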

Compound 3, half-maximal inhibitory concentration: > 100000 nM
Compound 3: a limit, no number (the forecaster's own chance of this, stated with the estimate: 85%); the middle value does not contradict the limit.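

No step among compound 1, compound 2 and compound 3 can be read, because all three values are limits and not numbers: the limit of > 100000 nM in this assay, at which 3 of the 3 values shown sit.

The compounds shown leave open how carboxy, sulfo and carboxymethyl on this aromatic carbon compare in this assay.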